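The source may report more compounds than this note shows. Statements on the series, on what has been measured and on what is new or still open speak of the compounds shown alone.

Series notes. Compound 1 `O=C(O)c1cccc(OCc2ccc(OCc3c(-c4c(Cl)cccc4Cl)noc3C3CC3)nc2C(F)(F)F)c1` gives in a functional assay on HEK293 cells for agonist activity at Bile acid receptor (Homo sapiens), read by a luciferase reporter (on this read-out higher numbers stand for an effect only at larger amounts of compound and lower numbers for an effect already at smaller amounts), a value of 33 nM. Compound 2 `O=C(O)c1ccc(OCc2ccc(OCc3c(-c4c(Cl)cccc4Cl)noc3C3CC3)nc2C(F)(F)F)cc1` gives in this assay a value of 38 nM. Among the measured compounds shown here, the only step so far, a 1.2-fold higher number from compound 1 to compound 2 (0.06 log units; within the scatter), moves the carboxylic acid around the terminal ring without leaving the scatter. Compound 2 thus stands at the higher of the two numbers, with compound 1 nearest and within the scatter of it, so no order between them can be stated.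

Compound 3 `CC(Oc1ccc(C(=O)O)cc1)c1ccc(OCc2c(-c3c(Cl)cccc3Cl)noc2C2CC2)nc1C(F)(F)F` is not yet measured. It differs from compound 2 by methyl in place of hydrogen on a saturated chain carbon bound to an aromatic carbon and an oxygen on an aromatic ring, which reads as (4-carboxyphenoxy)methyl to 1-(4-carboxyphenoxy)ethyl. For the measured compounds named here, no measured step touches this saturated chain carbon, so nothing in the data bears on it directly; the one step available concerns the ring and not the chain. The expectation is therefore a step of a 1.1-fold higher number from compound 2 to compound 3 (0.02 log units; within the scatter) that stays near the scatter, in no fixed direction. Compound 3 is estimated at 40 nM, within 15 nM to 120 nM.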

Compound 3, half-maximal effective concentration: 611 nM
For compound 3 the middle estimate is 15-fold (1.18 log units) below the measured one; measured number outside the range, above it.
By their numbers in this assay, from the lowest: compounds 1 and 2 (each within the scatter of the next); then compound 3.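

In this assay, the saturated chain carbon bound to an aromatic carbon and an oxygen on an aromatic ring proves sensitive: methyl in place of hydrogen there gives a 16-fold higher number from compound 2 to compound 3 (1.21 log units; beyond the scatter), whereas moving the carboxylic acid around the terminal ring had stayed within the scatter. The wider comparison, a 19-fold higher number from compound 1 to compound 3 (1.27 log units; beyond the scatter), combines that acid move with the added methyl and points the same way, so this small change on the chain carbon, and not the placement of the acid, marks the first clear separation in the series. Nothing available bears on why the methyl has this effect.

From the compounds shown here alone, it remains open how an ethyl or a fluorine on this same chain carbon would read. Also open, going by these compounds, is whether 1-(3-carboxyphenoxy)ethyl would give a step of similar size from compound 1.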